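Terminal amine swap on the enamide side chain

The source may hold more compounds than are shown below. What is called first, only, known or untested is meant among the compounds shown, and "the series" means these compounds.

In a functional assay on PC-3 cells (Homo sapiens) for antiproliferative activity, read by MTT assay, with a stated time of 72 h (on this read-out higher numbers stand for weaker inhibition and lower numbers for stronger inhibition), compound 3 `COc1cc2ncnc(N3CCCc4ccccc43)c2cc1NC(=O)/C=C/CN1CCCC1` gives 1740 nM, the lowest of the three numbers shown, although compound 2 `COc1cc2ncnc(N3CCc4ccccc43)c2cc1NC(=O)/C=C/CN1CCC(CO)CC1` with 2650 nM lies within the scatter of it; compound 1 `C/C=C/C(=O)Nc1cc2c(N3CCCc4ccccc43)ncnc2cc1OC` gives 7520 nM. For the measured compounds named here, the only single-place step measured, a 4.3-fold lower number from compound 1 to compound 3 (0.64 log units; beyond the scatter), marks the gain from attaching the pyrrolidine ring at the chain end. Compound 4 `COc1cc2ncnc(N3CCCc4ccccc43)c2cc1NC(=O)/C=C/CN1CCC(CO)CC1` carries the change (4-(hydroxymethyl)piperidin-1-yl in place of pyrrolidin-1-yl on a saturated chain carbon bound to a double-bonded chain carbon). Going by the values given here, no measured step covers this exchange directly; compound 2 bears the same entering group on another core and its number sits within the scatter of compound 3, so no shift beyond the scatter is expected in this assay. Compound 4 is therefore expected at 2000 nM, range 900 nM to 4500 nM. The expected step of a 1.1-fold higher number from compound 3 to compound 4 (0.06 log units; within the scatter) is within the scatter.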

Compound 4, half-maximal inhibitory concentration: 7150 nM
The estimate for compound 4 lay 3.6-fold (0.55 log units) below the measured number; measured number above the stated range.
By their numbers in this assay, from the lowest: compounds 3 and 2 (each within the scatter of the next); then compounds 4 and 1 (each within the scatter of the next).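

In this assay the chain end proves sensitive to the amine: 4-(hydroxymethyl)piperidin-1-yl in place of pyrrolidin-1-yl gives a 4.1-fold higher number from compound 3 to compound 4 (0.61 log units; beyond the scatter) and, in place of hydrogen, gives a 1.1-fold lower number from compound 1 to compound 4 (0.02 log units; within the scatter) so the gain seen with pyrrolidin-1-yl does not extend to this group. With this chain end held fixed, 1,2,3,4-tetrahydroquinolin-1-yl in place of 2,3-dihydro-1H-indol-1-yl gives a 2.7-fold higher number from compound 2 to compound 4 (0.43 log units; beyond the scatter) so the aromatic-carbon substituent also counts. Nothing available explains these steps. Going by these compounds, whether ring size or the hydroxymethyl group drives the change stays open; unsubstituted piperidin-1-yl would separate the two.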